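Fluoro on the benzoyl ring of a triazole thioether

The source may report more compounds than this note shows. Statements on the series, on what has been measured and on what is new or still open speak of the compounds shown alone.

Measured compounds in a functional assay on HCT-116 cells (Homo sapiens) for inhibition, read by MTT assay, with a stated time of 48 h; a higher number here means a weaker inhibitor, a lower number a stronger inhibitor:
Compound 1, `COc1ccc(CSc2nnc(-c3cc(OC)c(OC)c(OC)c3)n2-c2ccc(OC)cc2)cc1`: compound 1 gives 49600 nM.
Compound 2, `COc1ccc(-n2c(SCC(=O)c3ccccc3)nnc2-c2cc(OC)c(OC)c(OC)c2)cc1`: compound 2 is reported only as a limit of the assay, > 60000 nM.

Compound 2 thus stands at the weak end of the two numbers shown, with no number of its own; the limit of > 60000 nM in this assay, at which 1 of the 2 values shown sits, is all that is known of it. For the measured compounds named here, the single measured step, an at least 1.2-fold higher number from compound 1 to compound 2 (0.08 log units; that floor lies within the scatter), is the only step, and its floor lies within the scatter, so it shows little more than that the change to benzoyl did not sharpen inhibition.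

Compound 3, `COc1ccc(-n2c(SCC(=O)c3ccc(F)cc3)nnc2-c2cc(OC)c(OC)c(OC)c2)cc1`, differs from compound 2 by fluoro in place of hydrogen on an aromatic carbon, that is, phenyl to 4-fluorophenyl on the benzoyl group. Going by the values given here, no measured step bears on this change; the one step known concerns a different place. With compound 2 already at the limit, no move beyond the scatter can be grounded in the data, and a reading at the limit again is the likeliest outcome.

Compound 3 is therefore estimated at 70000 nM, within 30000 nM to 200000 nM. This corresponds to an expected step that the limit leaves unreadable from compound 2 to compound 3, no change beyond the scatter.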

Compound 3, half-maximal inhibitory concentration: > 60000 nM
Compound 3: only a limit was reported; the forecaster's own chance of this, stated with the estimate: 65%; the middle value lies beyond the limit too.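

In this assay compound 3 is reported only as a limit of the assay, > 60000 nM. On the benzoyl group, 4-fluorophenyl in place of phenyl therefore gives no number inside the range of the assay, and the step separating the two limits cannot be read. The one readable step, an at least 1.2-fold higher number from compound 1 to compound 3 (0.08 log units; that floor lies within the scatter), gives no sign of sharper inhibition, and the benzoyl compounds offer only a shared ceiling: the limit of > 60000 nM in this assay, at which 2 of the 3 values shown sit.

Going by these compounds, how far compound 2 and compound 3 lie from each other remains open, as does any effect of fluoro at this position on inhibition. Also open, on these data alone, is whether an amine or a carboxylic acid on the benzoyl ring, or a longer chain carrying the carbonyl, would bring a value inside the range of the assay.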